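A few compounds are considered here, and "the series" means these few. Any claim that something is new, unique, unknown or untested is made for them only; others in the source may bear on it.

Three compounds have been measured in an assay on CHO cells for displacement of a labelled ligand from Alpha-1A adrenergic receptor (Homo sapiens); on this read-out higher numbers stand for weaker inhibition and lower numbers for stronger inhibition:

Compound 1 `COc1cccc(OC)c1OCCNCCOc1ccccc1OCc1cccc(Cl)c1`: 0.251 nM
Compound 2 `COc1cccc(OC)c1OCCNCCOc1ccccc1OCc1ccc(Cl)cc1`: 0.251 nM
Compound 3 `COc1cccc(OC)c1OCCNCCOc1ccccc1OCc1cccc(C)c1`: 0.398 nM

Compound 2 stands level with compound 1 at the digits shown, the two together giving the lowest numbers of the three; compound 3 lies a short way above, a gap that is within the scatter. Compound 4 `COc1cccc(OC)c1OCCNCCOc1ccccc1OCc1ccc(C)cc1` differs from compound 2 by methyl in place of chloro on an aromatic carbon.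

Among the measured compounds shown here, two measured steps bear on this change. The exchange of chloro for methyl on an aromatic carbon has been seen once, as a 1.6-fold higher number from compound 1 to compound 3 (0.20 log units; within the scatter). Moving the same kind of group around the ring gave no change at the digits printed from compound 1 to compound 2 (within the scatter), and the combined change gave a 1.6-fold higher number from compound 2 to compound 3 (0.20 log units; within the scatter). All three steps are small and within the scatter, so the step from compound 2 to compound 4 is expected to be small as well, if anything a slightly higher number.

Compound 4 is therefore expected to give 0.4 nM, with a likely range from 0.2 nM to 0.8 nM. The expected step of a 1.6-fold higher number from compound 2 to compound 4 (0.20 log units; within the scatter) is estimated to stay within the usual scatter.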

Compound 4, inhibition constant: 2 nM
For compound 4 the middle estimate is 5.0-fold (0.70 log units) below the measured one, and the stated range ends below it.
By their numbers in this assay, from the lowest: compounds 1, 2 and 3 (each within the scatter of the next); then compound 4.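

In this assay, methyl in place of chloro does not carry one fixed penalty, as its size depends on which carbon of the ring holds the group: the same change on two cores in this assay, a 1.6-fold higher number (0.20 log units; within the scatter) from compound 1 to compound 3 and an 8.0-fold higher number (0.90 log units; beyond the scatter) from compound 2 to compound 4, 5.0-fold (0.70 log units) apart, beyond the scatter of two such steps. Where the group sits matters with methyl, since 4-methylphenyl in place of 3-methylphenyl gives a 5.0-fold higher number from compound 3 to compound 4 (0.70 log units; beyond the scatter), while the matching move with chloro gave no change at the digits printed from compound 1 to compound 2 (within the scatter). The 4-methylphenyl group of compound 4 thus stands apart from the other three groups, with an 8.0-fold higher number from compound 2 to compound 4 (0.90 log units; beyond the scatter) and an 8.0-fold higher number from compound 1 to compound 4 (0.90 log units; beyond the scatter).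

As far as these compounds go, whether fluoro, methoxy or trifluoromethyl on the same carbon would behave like chloro or like methyl remains open. Also open, from the compounds shown here alone, is how a second group on this ring, such as another methyl, would change the picture.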